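The source may report more compounds than this note shows. Statements on the series, on what has been measured and on what is new or still open speak of the compounds shown alone.

Compound 1 `CCOC(=O)c1ccc(-c2ccc(N(C)C)nn2)cc1`: > 25000 nM
Compound 2 `CCOC(=O)c1ccc(-c2ccc(OC(C)C)nn2)cc1`: > 25000 nM

In a functional assay on MDA-MB-231 cells (Homo sapiens) for antiproliferative activity, with a stated time of 48 h (on this read-out lower numbers stand for stronger inhibition and higher numbers for weaker inhibition), compound 1 gives > 25000 nM, which is a limit and not a number. Compound 2 gives > 25000 nM, which is also a limit. Both compounds therefore sit at the same edge of the assay, as the limit of > 25000 nM in this assay, at which 2 of the 2 values shown sit, records. Compound 3 `CCCCOc1ccc(-c2ccc(C(=O)OCC)cc2)nn1` keeps the shared core and changes one chain: butyl in place of isopropyl on an oxygen on an aromatic ring. For the measured compounds named here, the only measured step bearing on this is a step that the two limits leave unreadable from compound 1 to compound 2, so it offers no size or direction to carry forward, and no clear change is expected. For compound 3 the estimated value is 30000 nM, within an expected range of 12000 nM to 60000 nM. The expected change is a step that the limit leaves unreadable from compound 2 to compound 3.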

Compound 3, half-maximal inhibitory concentration: > 25000 nM
Compound 3: only a limit was reported; the forecaster's own chance of this, stated with the estimate: 75%; the middle value lies beyond the limit too.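

Compound 3 also gives only a limit, so no step among compound 1, compound 2 and compound 3 can be read: the limit of > 25000 nM in this assay, at which 3 of the 3 values shown sit.

The compounds shown leave open whether any change to the shared core gives a readable value.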